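Pyrazoline sulfonamides: antiproliferative series, next analogue

This account rests on a few compounds, and the source may have more. Where it says the series, first, only, none or still open, it means among the compounds named here.

Measured so far:
compound 1, `Cc1cc(O)c(C2=NN(c3ccc(S(N)(=O)=O)cc3)C(c3ccccc3Cl)C2)cc1Cl`, 100000 nM in a functional assay on K562 cells (Homo sapiens) for antiproliferative activity, with a stated time of 48 h; on this read-out lower numbers stand for stronger inhibition of growth and higher numbers for weaker inhibition of growth
compound 2, `Cc1cc(O)c(C2=NN(c3ccc(S(N)(=O)=O)cc3)C(/C=C/c3ccccc3)C2)cc1Cl`, 87500 nM in this assay

Among the compounds with values here, compound 2 and compound 1 are the only two numbers in hand, and the two sit within the scatter of each other: a 1.1-fold lower number from compound 1 to compound 2 (0.06 log units; within the scatter). Neither compound shows notable growth inhibition in this assay.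

Compound 3, `COc1ccc(C2CC(c3cc(Cl)c(C)cc3O)=NN2c2ccc(S(N)(=O)=O)cc2)cc1OC`, has not yet been measured in this assay. Relative to compound 2 the change is 3,4-dimethoxyphenyl in place of 2-phenylethenyl on a saturated ring carbon. Within the data shown here, the only measured step, from compound 1 to compound 2, swaps groups at this same saturated ring carbon and stays within the scatter; no step in hand concerns a 3,4-dimethoxyphenyl group at this position, so that step offers only weak guidance. The expectation is therefore a step of no size beyond the scatter, a 1.0-fold higher number from compound 2 to compound 3 (0.01 log units; within the scatter). Compound 3 is accordingly estimated at 90000 nM in this assay, with a range from 45000 nM to 100000 nM.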

Compound 3, concentration for total growth inhibition: 100000 nM
The estimate for compound 3 lay 1.1-fold (0.05 log units) below the measured number, and the stated range covers the measured number.
By their numbers in this assay, from the lowest: compounds 2, 1 and 3 (each within the scatter of the next).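

In this assay, placing 3,4-dimethoxyphenyl on the saturated ring carbon gives a 1.1-fold higher number from compound 2 to compound 3 (0.06 log units; within the scatter), and the comparison with the 2-chlorophenyl group gives no change at the digits printed from compound 1 to compound 3 (within the scatter). The three groups tried at this position, 2-chlorophenyl, 2-phenylethenyl and 3,4-dimethoxyphenyl, therefore all lie within the scatter of one another, and the two hydrogen-bond acceptors that enter with 3,4-dimethoxyphenyl bring no separation from compound 2. No measurement in hand bears on the reason for this result.

Still open, as far as these compounds go, is whether a group of a different kind at this carbon, such as a carboxylic acid, an amine or a longer alkyl chain, would separate from these three. The compounds shown also leave open whether replacing the 4-sulfamoylphenyl group would move the number.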